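A few compounds are considered here, and "the series" means these few. Any claim that something is new, unique, unknown or untested is made for them only; others in the source may bear on it.

Compound 1 `CCN1CCN(c2nc(Nc3ccc(C(=O)NC4CC(C)(C)N([O])C(C)(C)C4)cc3)ncc2[N+](=O)[O-])CC1` in a functional assay on LoVo cells (Homo sapiens) for antiproliferative activity, read by MTT assay, with a stated time of 48 h (a lower number here means a stronger inhibitor, a higher number a weaker inhibitor), gives 39700 nM. Compound 2 `Cc1cc(Nc2nc(Nc3ccc(C(=O)NC4CC(C)(C)N([O])C(C)(C)C4)cc3)ncc2[N+](=O)[O-])n[nH]1` in this assay returns only a limit of the assay, > 100000 nM. Compound 2 thus stands at the limit described by the limit of > 100000 nM in this assay, at which 1 of the 2 values shown sits. Among the compounds with values here, the single measured step, an at least 2.5-fold higher number from compound 1 to compound 2 (0.40 log units; beyond the scatter), is at least modest, so compound 2 is the weaker of the two. Compound 3 `CCOC(=O)c1csc(Nc2nc(Nc3ccc(C(=O)NC4CC(C)(C)N([O])C(C)(C)C4)cc3)ncc2[N+](=O)[O-])n1` differs from compound 2 by 4-(ethoxycarbonyl)-1,3-thiazol-2-yl in place of 5-methyl-1H-pyrazol-3-yl on a nitrogen on an aromatic ring. Within the data shown here, no measured step touches this exchange, so the step of a number no higher from compound 2 to compound 3 (the limit leaves the size open) is expected to stay within the scatter. Compound 3 is therefore expected near 100000 nM, between 30000 nM and 300000 nM, quite possibly again reported only as a limit.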

Compound 3, half-maximal inhibitory concentration: 12500 nM
For compound 3 the middle estimate is 8.0-fold (0.90 log units) above the measured one; the whole stated range lies above it.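

On a nitrogen on an aromatic ring, 4-(ethoxycarbonyl)-1,3-thiazol-2-yl in place of 5-methyl-1H-pyrazol-3-yl gives an at least 8.0-fold lower number from compound 2 to compound 3 (0.90 log units; beyond the scatter) in this assay, so the activity responds to the group held here. The change to (4-(ethoxycarbonyl)-1,3-thiazol-2-yl)amino gives a 3.2-fold lower number from compound 1 to compound 3 (0.50 log units; beyond the scatter), so an amino-linked ring need not fall behind 4-ethylpiperazin-1-yl. The first step has no fixed size because compound 2 gives only a limit of the assay: the limit of > 100000 nM in this assay, at which 1 of the 3 values shown sits.

Going by these compounds, whether the ethoxycarbonyl or the thiazole ring carries the change stays open. An unsubstituted 1,3-thiazol-2-yl, or a carboxylic acid in place of the ester, would bear on this.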